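Compound 2 and its mirror image, compound 4

A few compounds are considered here, and "the series" means these few. Any claim that something is new, unique, unknown or untested is made for them only; others in the source may bear on it.

In an ADME assay on MDCK cells (Canis lupus familiaris) for permeability, read by LC-MS, with a stated time of 90 min, tested at 2 uM (a lower number here means that the compound crosses the layer more slowly, a higher number that the compound crosses the layer faster), compound 2 `Cc1cc(C)c(CN2CCc3c(Cl)cc([C@H](CO)[C@H]4CCCO4)c(Cl)c3C2=O)c(=O)[nH]1` gives 4.1 10^-6 cm/s, from a single reading. Compound 1 `COC(c1cc(Cl)c2c(c1Cl)C(=O)N(Cc1c(C)cc(C)[nH]c1=O)CC2)C1CCOC1` gives 17.1 10^-6 cm/s; 18.7 10^-6 cm/s; 15.4 10^-6 cm/s; 18.4 10^-6 cm/s (4 entries) over repeated runs. Compound 3 `CCOC(c1cc(Cl)c2c(c1Cl)C(=O)N(Cc1c(C)cc(C)[nH]c1=O)CC2)C1CS(=O)(=O)C1` gives 12 10^-6 cm/s; 7.7 10^-6 cm/s (2 entries). The number for compound 2 lies clearly under those of compound 1.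

Compound 4 `Cc1cc(C)c(CN2CCc3c(Cl)cc([C@@H](CO)[C@@H]4CCCO4)c(Cl)c3C2=O)c(=O)[nH]1` relates to compound 2 in one way only: the two compounds have the same atoms and bonds and differ only in configuration as drawn: 2 of 2 stereo elements differ (all stereocentres are inverted: mirror images); a stereocentre at a saturated chain carbon is drawn R in compound 2 and S in compound 4; a stereocentre at a saturated ring carbon is drawn R in compound 2 and S in compound 4. The two compounds are mirror images, with the same atoms and bonds. Among the compounds with values here, no measured pair here shows what such an inversion does in this assay, so the estimate starts from compound 2 at 4.1 10^-6 cm/s. The expected step is no change at the digits printed from compound 2 to compound 4 (within the scatter), in neither direction and no larger than the scatter. The estimated value for compound 4 is 4.1 10^-6 cm/s, with an expected range of 2.2 10^-6 cm/s to 7.8 10^-6 cm/s.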

Compound 4, apparent permeability: 4.3 10^-6 cm/s
The estimate for compound 4 lay 1.0-fold (0.02 log units) below the measured number; the measured number falls inside the stated range.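

In this assay, inverting both stereocentres gives a 1.0-fold higher number from compound 2 to compound 4 (0.02 log units; within the scatter). Within the data shown here, this is the first pair here that differs in configuration alone, and its two numbers lie within the scatter of each other. At these two carbons, then, the full mirror-image change leaves the reading unchanged for this pair, something compound 1 and compound 3 could not show.

Going by these compounds, what inverting only one of the two stereocentres would do remains open. So does whether the same would hold with an amine or a carboxylic acid on that side chain.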